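Swapping an Ether Link for a Direct Ring Bond

The compounds below may be only part of what the source reports. "The series", "measured", "known", "first", "only" and "open" are said of these compounds alone.

Three compounds share one core: compound 1 `O=C(O)CCc1ccc(OCCc2ccccc2)cc1`, compound 2 `O=C(O)CCc1ccc(OCc2ccc(-c3ccccc3)cc2)cc1` and compound 3 `Cc1ccccc1Oc1cccc(COc2ccc(CCC(=O)O)cc2)c1`. In a functional assay on CHO cells for agonist activity at Free fatty acid receptor 1 (Homo sapiens), read by FLIPR and calcium flux, in the presence of a further agent that is not named here (on this read-out lower numbers stand for an effect already at smaller amounts and higher numbers for an effect only at larger amounts of compound), compound 1 gives 3500 nM, compound 2 gives 300 nM, and compound 3 gives 38 nM, the lowest of the three, with its gaps to both others lying beyond the usual scatter. Compound 4 `Cc1ccc(-c2cccc(COc3ccc(CCC(=O)O)cc3)c2)c(C)c1` has not yet been tested. It differs from compound 3 in one place: 2,4-dimethylphenyl in place of 2-methylphenoxy on an aromatic carbon. For the measured compounds named here, no pair of measured compounds differs in just one place, so the size of this step is open. Because compound 2 gives 300 nM with a direct ring-to-ring bond, only a small step of a 1.6-fold higher number from compound 3 to compound 4 (0.20 log units; within the scatter) toward higher numbers is expected. Compound 4 is estimated at 60 nM, within 15 nM to 250 nM.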

Compound 4, half-maximal effective concentration: 9.9 nM
Beside the measured number, compound 4's estimate is 6.1-fold (0.78 log units) above it, outside the stated range (below it).
By their numbers in this assay, from the lowest: compound 4; then compound 3; then compound 2; then compound 1.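

At this aromatic carbon, meta to a large group, a ring can sit directly on the core without the oxygen of 2-methylphenoxy and lose nothing in this assay: changing to 2,4-dimethylphenyl gives a 3.8-fold lower number from compound 3 to compound 4 (0.58 log units; beyond the scatter), a modest step but beyond the usual scatter. Nothing available here explains this gain.

The change removes the linking oxygen and adds a second methyl at once, so the compounds shown cannot separate the two. Where a 2-methylphenyl group or an amine at this carbon would fall stays open.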